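The source may report more compounds than this note shows. Statements on the series, on what has been measured and on what is new or still open speak of the compounds shown alone.

Compound 1 `COc1ccc(C2=C(c3cc(OC)c(OC)c(OC)c3)C(=O)C(OC(C)=O)C2)cc1OC(C)C`: > 100 ug/mL (a limit)
Compound 2 `COc1ccc(C2=C(c3cc(OC)c(OC)c(OC)c3)C(=O)CC2C)cc1C(=O)O`: > 100 ug/mL (a limit)

In an ADME assay on PA-1 cells (Homo sapiens) for cytotoxicity, read by MTT assay, with a stated time of 72 h (on this read-out lower numbers stand for stronger inhibition and higher numbers for weaker inhibition), compound 1 gives > 100 ug/mL, which is a limit of the assay and not a number. For the measured compounds named here, both measured compounds rest there, as the limit of > 100 ug/mL in this assay, at which 2 of the 2 values shown sit, records, so no measured step is available as a guide.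

Compound 3 `COc1ccc(C2=C(c3cc(OC)c(OC)c(OC)c3)C(=O)C(OC(C)=O)C2)cc1` has hydrogen in place of isopropoxy on an aromatic carbon. In this assay no change beyond the scatter is expected, and the estimated move is an at least 1.1-fold lower number from compound 1 to compound 3 (0.04 log units; that floor lies within the scatter). For compound 3 the estimated value is 90 ug/mL, with an expected range from 25 ug/mL to 200 ug/mL.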

Compound 3, half-maximal inhibitory concentration: < 1 ug/mL
Compound 3 gave a limit, no number; the forecaster's own chance of this, stated with the estimate: 65%; middle value at least 90-fold (1.95 log units) from the limit.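

In this assay, hydrogen in place of isopropoxy on an aromatic carbon, ortho to a methoxy group, gives an at least 100-fold lower number from compound 1 to compound 3 (2.00 log units; beyond the scatter). Both ends of this step are limits of the assay, not numbers. The earlier compounds shown here could not show this, as they sat together at one limit, whereas this single place now separates compound 1 from compound 3.

Going by these compounds, whether a hydroxyl, an amine or an ethoxy group at this place would read like compound 3 or like compound 1 stays open. On these data alone, the actual value of compound 3 also stays open.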